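Working notes on solubility in a four-compound series

The source may report more compounds than this note shows. Statements on the series, on what has been measured and on what is new or still open speak of the compounds shown alone.

Measured in a physicochemical assay for solubility, read by HPLC, at pH 2; on this read-out lower numbers stand for lower solubility and higher numbers for higher solubility:
compound 1 `Cc1cc(C#N)cc(C)c1Oc1cc(Nc2ccc(C#N)cc2)c(N)cc1CNCCCO` gives 290 ug/mL
compound 2 `COCc1cc(N)c(Nc2ccc(C#N)cc2)cc1Oc1c(C)cc(C#N)cc1C` gives 3.75 ug/mL
compound 3 `CC(=O)OCc1cc(N)c(Nc2ccc(C#N)cc2)cc1Oc1c(C)cc(C#N)cc1C` gives 16.7 ug/mL

Compound 2 stands lowest of the three numbers in this assay. Its nearest neighbour is reached by a 4.5-fold higher number from compound 2 to compound 3 (0.65 log units; beyond the scatter), its furthest by a 77-fold lower number from compound 1 to compound 2 (1.89 log units; beyond the scatter); the remaining step is a 17-fold lower number from compound 1 to compound 3 (1.24 log units; beyond the scatter).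

Compound 4 `COCc1cc(N)c(Nc2ccc(C#N)cc2)cc1Oc1c(C)cc(/C=C/C#N)cc1C` differs from compound 2 by 2-cyanoethenyl in place of cyano on an aromatic carbon. None of the three measured steps touches this change; all of them concern the group on the saturated chain carbon. Among the compounds with values here, no comparable step is therefore available, and the expectation rests on the value of compound 2 alone, with a change expected to stay near the scatter, a 1.5-fold lower number from compound 2 to compound 4 (0.18 log units; within the scatter). Compound 4 is thus expected to give 2.5 ug/mL, with a range from 0.7 ug/mL to 9 ug/mL.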

Compound 4, solubility: 1.7 ug/mL
Compound 4: middle estimate off by 1.5-fold (0.17 log units), on the high side, and the stated range covers the measured number.
By their numbers in this assay, from the lowest: compound 4; then compound 2; then compound 3; then compound 1.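

In this assay, this is the only step shown at the aromatic carbon meta to two methyl groups, and 2-cyanoethenyl in place of cyano gives a 2.2-fold lower number from compound 2 to compound 4 (0.34 log units; beyond the scatter). The hydrogen-bond donor count, acceptor count and net charge stay the same across this change, so the step is not accompanied by a difference in any of them. No measurement shown bears on the reason for the step.

On these data alone, whether the same step would appear with the (3-hydroxypropyl)amino group of compound 1 remains open. So does the reading with an amine or a carboxylic acid at this aromatic carbon.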